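From Methyl to Benzyl in a Cytotoxicity Series

The compounds below may be only part of what the source reports. "The series", "measured", "known", "first", "only" and "open" are said of these compounds alone.

Compound 1 `CCOC(=O)C[n+]1cccc(O)c1`: > 200000 nM
Compound 2 `O=C(O[C@H]1C[C@H](n2cc(F)c(=O)[nH]c2=O)O[C@@H]1COP(=O)(O)Oc1ccc2ncccc2c1)c1ccccc1`: 1300 nM
Compound 3 `C[n+]1cccc(OP(=O)([O-])OC[C@H]2O[C@@H](n3cc(F)c(=O)[nH]c3=O)C[C@@H]2OC(=O)c2ccccc2)c1`: 3480 nM

These values come from a functional assay on T98G cells (Homo sapiens) for cytotoxicity, read by MTT assay, with a stated time of 48 h; a lower number here means a stronger inhibitor, a higher number a weaker inhibitor. For compound 1, the entry > 200000 nM is a limit of the assay and not a number.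

Compound 3 has the higher of the two true numbers. Compound 3 gives 3480 nM and compound 2 gives 1300 nM, a gap beyond the usual scatter, which makes compound 3 the weaker inhibitor of this pair.

Compound 4 `O=C(O[C@H]1C[C@H](n2cc(F)c(=O)[nH]c2=O)O[C@@H]1COP(=O)([O-])Oc1ccc[n+](Cc2ccccc2)c1)c1ccccc1` differs from compound 3 at one place: phenyl in place of hydrogen on a saturated chain carbon bound to an aromatic nitrogen. This puts phenyl in place of hydrogen on a saturated chain carbon bound to an aromatic nitrogen, turning methyl into benzyl.

Among the compounds with values here, no measured pair shows this change, so the forecast is uncertain. A modest move towards stronger inhibition in this assay is expected, since compound 2 at 1300 nM shows that lower numbers are reachable in this series. The expected change is a 1.7-fold lower number from compound 3 to compound 4 (0.24 log units; within the scatter). For compound 4 the estimated value is 2000 nM, with an expected range of 700 nM to 6000 nM.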

Compound 4, half-maximal inhibitory concentration: 2600 nM
The estimate for compound 4 lay 1.3-fold (0.11 log units) below the measured number; the measured number falls inside the stated range.
By their numbers in this assay, from the lowest: compounds 2, 4 and 3 (each within the scatter of the next, the first and the last beyond it). At a limit, above all of these: compound 1.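

In this assay, putting phenyl in place of hydrogen on a saturated chain carbon bound to an aromatic nitrogen, which turns methyl into benzyl, gives a 1.3-fold lower number from compound 3 to compound 4 (0.13 log units; within the scatter). Before this pair, no measured compounds differed only at this place, and it now shows that a group of six heavy atoms can sit there while the two numbers remain indistinguishable. The data on hand give no explanation for how this step came out.

From the compounds shown here alone, what stays open is whether this holds only for benzyl or also for other groups at the same place, such as a longer alkyl chain or a chain ending in an amine or a carboxylic acid. Going by these compounds, it is also open whether a fluorine or a methoxy group on the phenyl ring would move the number in this assay beyond the scatter.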